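Trading bromo for chloro on a growth inhibitor

The source may report more compounds than this note shows. Statements on the series, on what has been measured and on what is new or still open speak of the compounds shown alone.

Among the measured compounds shown here, in a functional assay on SK-OV-3 cells (Homo sapiens) (a lower number here means a stronger inhibitor of growth, a higher number a weaker inhibitor of growth), compound 1 `O=S(=O)(/C=C/c1ccccc1)Cc1ccc(Nc2ncnc3ccccc23)cc1` gives 5000 nM, while compound 2 `O=S(=O)(/C=C/c1ccc(Br)cc1)Cc1ccc(Nc2ncnc3ccccc23)cc1` gives 1000 nM, the lower of the two numbers so far. Compound 3 `O=S(=O)(/C=C/c1ccc(Cl)cc1)Cc1ccc(Nc2ncnc3ccccc23)cc1` differs from compound 2 by chloro in place of bromo on an aromatic carbon, with chloro in place of bromo on an aromatic carbon. For the measured compounds named here, the only measured step that bears on this is the bromo-for-hydrogen change, a 5.0-fold lower number from compound 1 to compound 2 (0.70 log units; beyond the scatter). Compound 3 still carries a group at that place, so a smaller step is expected, probably within the scatter and slightly upward: a 1.4-fold higher number from compound 2 to compound 3 (0.15 log units; within the scatter). The estimated value for compound 3 is 1400 nM, with an expected range of 500 nM to 4000 nM.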

Compound 3, concentration for 50% growth inhibition: 54000 nM
Beside the measured number, compound 3's estimate is 39-fold (1.59 log units) below it; the whole stated range lies below it.
By their numbers in this assay, from the lowest: compound 2; then compound 1; then compound 3.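

Bromo and chloro are not interchangeable at this position: in this assay, swapping one for the other gives a 54-fold higher number from compound 2 to compound 3 (1.73 log units; beyond the scatter). Chloro does more than lose the gain seen with bromo, since an 11-fold higher number from compound 1 to compound 3 (1.03 log units; beyond the scatter), so a substituent at this place can move the number in either direction relative to hydrogen. Nothing available explains why these two halogens differ so sharply. On these data alone, whether fluoro, iodo, methoxy or an amine at this place would behave like bromo or like chloro remains open.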